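The source may report more compounds than this note shows. Statements on the series, on what has been measured and on what is new or still open speak of the compounds shown alone.

Measured so far:
Compound 1, `Cc1ccc(CN(C)CCCn2c(=O)oc3ccccc32)c(C)c1`: 1830 nM
Compound 2, `Cc1cccc(CN(C)CCCCn2c(=O)oc3ccccc32)c1`: 102 nM
Compound 3, `Cc1ccc(CN(C)CCCCn2c(=O)oc3ccccc32)cc1`: 97 nM

In an assay on membranes from liver for displacement of a labelled ligand from Sigma non-opioid intracellular receptor 1 (Rattus norvegicus), read by scintillation counting (on this read-out higher numbers stand for weaker inhibition and lower numbers for stronger inhibition), compound 1 gives the highest of the three numbers, far apart from the other two: compound 2 gives 102 nM and compound 3 gives 97 nM, both beyond the scatter from compound 1. Compound 4, `CN(CCCn1c(=O)oc2ccccc21)Cc1ccccc1`, has not yet been measured. It differs from compound 1 in one place: phenyl in place of 2,4-dimethylphenyl on a saturated chain carbon bound to an amine nitrogen.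

Among the compounds with values here, only one step between measured compounds is known, a 1.1-fold lower number from compound 2 to compound 3 (0.02 log units; within the scatter), and it concerns where a single methyl sits on the ring, not how many methyls the ring carries. Compounds 2 and 3 also differ from compound 1 in the chain between the amine nitrogen and the shared core, so their gap to compound 1 cannot be assigned to the methyl groups alone. Within the data shown here, no measured step therefore bears directly on the change from compound 1 to compound 4, and any expectation in this assay rests on weak ground. Compound 4 is expected to give 800 nM, within 200 nM to 3000 nM. That amounts to an expected step of a 2.3-fold lower number from compound 1 to compound 4 (0.36 log units; beyond the scatter), a modest move toward a lower number, with the range wide enough to include no change beyond the scatter.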

Compound 4, inhibition constant: 223 nM
Compound 4: the middle estimate sits 3.6-fold (0.55 log units) above what was measured; low and high end bracket the measured number.
By their numbers in this assay, from the lowest: compounds 3 and 2 (each within the scatter of the next); then compound 4; then compound 1.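

In this assay, phenyl in place of 2,4-dimethylphenyl on a saturated chain carbon bound to an amine nitrogen gives an 8.2-fold lower number from compound 1 to compound 4 (0.91 log units; beyond the scatter) with the chain left the same, so the number of methyl groups on this ring can matter at this position. Within the data shown here, the only earlier step, a 1.1-fold lower number from compound 2 to compound 3 (0.02 log units; within the scatter) within the scatter, moved a single methyl on a different chain and left the number of methyl groups unchanged, whereas taking away both methyl groups here produces a change beyond the scatter. Nothing measured here explains why this change lowers the number.

The compounds shown do not reveal whether one methyl group accounts for the step or both are needed, as neither 2-methylphenyl nor 4-methylphenyl appears on the chain of compound 4, and they do not show how other ring groups, such as methoxy or chlorine, would behave at this position. The effect of chain length also stays open, as no unsubstituted phenyl compound carries the longer chain of compound 2 and compound 3, and no pair shown differs in the chain alone.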